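From Allyl to Benzyl: an Expected Modest Gain

A few compounds are considered here, and "the series" means these few. Any claim that something is new, unique, unknown or untested is made for them only; others in the source may bear on it.

Two compounds have so far been measured in a functional assay on MCF7 cells (Homo sapiens) for cytotoxicity, read by MTT assay, with a stated time of 72 h; on this read-out higher numbers stand for weaker inhibition of growth and lower numbers for stronger inhibition of growth:

Compound 1 `C=CCOC(=O)Nc1ccc([Se]C#N)cc1` gives 15000 nM.
Compound 2 `N#C[Se]c1ccc(NC(=O)Oc2ccccc2)cc1` gives 4000 nM.

Of these two numbers, compound 1 holds the higher one, meaning it inhibits growth less strongly. The nearest comparison is a 3.8-fold lower number from compound 1 to compound 2 (0.57 log units; beyond the scatter), brought about by phenyl in place of allyl on an oxygen next to a carbonyl group.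

Compound 3 `N#C[Se]c1ccc(NC(=O)OCc2ccccc2)cc1` has not yet been measured. It differs from compound 1 by phenyl in place of vinyl on a saturated chain carbon bound to an oxygen next to a carbonyl group. In compound 3 the phenyl thus stands on a saturated chain carbon bound to the oxygen, whereas in compound 2 it sits on the oxygen next to the carbonyl group itself. Among the measured compounds shown here, the only measured step that bears on this change is a 3.8-fold lower number from compound 1 to compound 2 (0.57 log units; beyond the scatter), a modest step that lies beyond the scatter. A change of the same kind is expected to move this assay in the same direction, by a step of similar or somewhat smaller size.

Compound 3 is therefore estimated at 6000 nM, with a range from 2500 nM to 15000 nM. This corresponds to an expected 2.5-fold lower number from compound 1 to compound 3 (0.40 log units; beyond the scatter).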

Compound 3, concentration for 50% growth inhibition: 8700 nM
For compound 3 the middle estimate is 1.5-fold (0.16 log units) below the measured one; the measured number falls inside the stated range.
By their numbers in this assay, from the lowest: compound 2; then compounds 3 and 1 (each within the scatter of the next).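

In this assay, phenyl in place of vinyl on a saturated chain carbon bound to an oxygen next to a carbonyl group gives a 1.7-fold lower number from compound 1 to compound 3 (0.24 log units; within the scatter) and so does not separate the two groups, even though phenyl brings a six-membered aromatic ring where vinyl has a double bond outside any aromatic ring. The earlier change, with a 3.8-fold lower number from compound 1 to compound 2 (0.57 log units; beyond the scatter) as its result, was beyond the scatter, so among these compounds bringing in a phenyl group does not always produce a clear shift, and compound 3 is the case that goes against such a rule. No further measurement is available to explain why one step stands beyond the scatter and the other within it.

The compounds shown leave open whether a longer chain carrying the phenyl group would give a number clearly different from that of compound 1. They also leave open how an amine or a carboxylic acid on the phenyl ring of compound 3 would move the number in this cell assay, in either direction.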